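Dropping One Decyloxy Chain from an E-Selectin Binder

This account rests on a few compounds, and the source may have more. Where it says the series, first, only, none or still open, it means among the compounds named here.

Measured compounds:
Compound 1 `CCCCCCCCCCOc1cc(OCCCCCCCCCC)cc(OCCCCCC(=O)N(c2cccc(C(=O)O)c2)c2cccc(C(=O)O)c2)c1`: "not determined" (no result reported)
Compound 2 `CCCCCCCCCCOc1cc(OCCCCCCCCCC)cc(OCCCCCC(=O)N(c2ccc(C(=O)O)cc2)c2cccc(C(=O)O)c2)c1`: "not determined" (no result reported)
Compound 3 `CCCCCCCCCCOc1cc(OCCCCCCCCCC)cc(OCCCCCC(=O)N(Cc2ccc(C(=O)O)cc2)c2cccc(C(=O)O)c2)c1`: 43%

Three compounds share a core carrying long decyloxy chains and two benzoic acid arms joined through an amide. In an assay on isolated protein for binding affinity to E-selectin (Homo sapiens), read by ELISA, tested at 100 uM (a higher number here means more inhibition at the concentration tested (going by the name of the read-out), a lower number less inhibition), compound 3 gives 43%. For compound 1 the read-out in this assay is "not determined" (no result reported), and for compound 2 it is "not determined" (no result reported); neither offers a number to set beside compound 3. So compound 3 stands alone as the only compound with a measured result, and no step between measured compounds is available to show how any change in structure moves the read-out.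

Compound 4 `CCCCCCCCCCOc1cccc(OCCCCCC(=O)N(Cc2ccc(C(=O)O)cc2)c2cccc(C(=O)O)c2)c1` is the next compound to be measured. It differs from compound 3 by hydrogen in place of decyloxy on an aromatic carbon. For the measured compounds named here, with no measured step to lean on, the expectation rests on the single value of compound 3 and on the size of the group that is removed. Taking away a whole decyloxy chain is a large change, so the read-out in this assay is expected to move downward by a step of a number 18 percentage points lower from compound 3 to compound 4 (beyond the scatter), beyond the usual scatter. For compound 4 the estimate is 25%, expected to lie between 5% and 45%.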

Compound 4, a percentage reported as inhibition, at one concentration (the size of the read-out at that concentration, not a potency): 42%
For compound 4 the middle estimate is 17 percentage points below the measured one; the range from low to high includes it.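

In this assay, hydrogen in place of decyloxy on this aromatic carbon gives a number 1 percentage points lower from compound 3 to compound 4 (within the scatter), so the read-out does not tell the two compounds apart. For the compounds shown here, this is the first comparison between two measured compounds, and it shows that a chain of this size can leave this position with no change in inhibition that stands out from the scatter at the concentration tested. Nothing shown explains why the read-out holds when the chain is removed.

The compounds shown leave open what a smaller group, such as methoxy, or a different one, such as an amine or a carboxylic acid, would do on this aromatic carbon, and whether the remaining decyloxy chain could also be replaced by hydrogen. On these data alone, the read-out also comes from a single concentration, so it remains open whether compound 3 and compound 4 would still match across a range of concentrations.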